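Methyl on the hydroxy group of compound 3

The source may hold more compounds than are shown below. What is called first, only, known or untested is meant among the compounds shown, and "the series" means these compounds.

In a functional assay on MCF7 cells (Homo sapiens) for cytotoxicity, read by MTT assay, with a stated time of 72 h (on this read-out lower numbers stand for stronger inhibition and higher numbers for weaker inhibition), compound 2 `COc1cc(C=C2C(=O)N(c3ccc(Cl)cc3)N(c3ccc(Cl)cc3)C2=O)ccc1O` gives 22800 nM and compound 3 `COc1cccc(C=C2C(=O)N(c3ccc(Cl)cc3)N(c3ccc(Cl)cc3)C2=O)c1O` gives 26700 nM on the same read-out. These two sit level, with a 1.2-fold higher number from compound 2 to compound 3 (0.07 log units; within the scatter) lying within the scatter. Compound 1 `CN(C)c1ccc(C=C2C(=O)N(c3ccc(Cl)cc3)N(c3ccc(Cl)cc3)C2=O)cc1` gives > 128000 nM as a limit of the assay and not a number. Compound 3 stands clear of that limit, with an at least 4.7-fold lower number from compound 1 to compound 3 (0.68 log units; beyond the scatter) lying beyond the scatter.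

Compound 4 `COc1cccc(C=C2C(=O)N(c3ccc(Cl)cc3)N(c3ccc(Cl)cc3)C2=O)c1OC` differs from compound 3 by methyl in place of hydrogen on an oxygen on an aromatic ring in a single place, with methyl in place of hydrogen on an oxygen on an aromatic ring, which turns 2-hydroxy-3-methoxyphenyl into 2,3-dimethoxyphenyl. Among the compounds with values here, no measured step makes this change directly. Both an at least 5.6-fold lower number from compound 1 to compound 2 (0.74 log units; beyond the scatter) and an at least 4.7-fold lower number from compound 1 to compound 3 (0.68 log units; beyond the scatter) start from a compound without a hydroxy and bear on the question, but they also remove 4-(dimethylamino)phenyl and give only a loose guide. In this assay a modest move towards higher numbers is therefore expected, smaller than those two steps suggest at face value. The expected step is a 2.1-fold higher number from compound 3 to compound 4 (0.31 log units; beyond the scatter) in size and direction. For compound 4 the estimated value is 55000 nM with 18000 nM to 128000 nM as its expected range.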

Compound 4, half-maximal inhibitory concentration: 11900 nM
For compound 4 the middle estimate is 4.6-fold (0.66 log units) above the measured one; measured number below the stated range.
By their numbers in this assay, from the lowest: compounds 4, 2 and 3 (each within the scatter of the next, the first and the last beyond it). At a limit, above all of these: compound 1.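

In this assay methyl on the oxygen of compound 3 gives a 2.2-fold lower number from compound 3 to compound 4 (0.35 log units; beyond the scatter) and so turns 2-hydroxy-3-methoxyphenyl into 2,3-dimethoxyphenyl with a lower number and not a higher one, which shows that the hydrogen on this oxygen is not needed for cytotoxicity at this level. Within the data shown here, the earlier compounds could not show this, since the only one without a hydroxy group, compound 1, also carries 4-(dimethylamino)phenyl in place of the whole substituted ring, while the new comparisons read a 1.9-fold lower number from compound 2 to compound 4 (0.28 log units; within the scatter) and an at least 10-fold lower number from compound 1 to compound 4 (1.03 log units; beyond the scatter) and thus place a compound without a hydroxy group on the measured scale with those that have one. Compound 1 with > 128000 nM remains a limit of the assay and not a number.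

Nothing measured here accounts for the step from hydroxy to methoxy. The compounds shown leave open whether a longer chain such as ethyl on the same oxygen continues this trend, and whether an amine or a carboxylic acid in place of the methoxy group would be tolerated.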